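A few compounds are considered here, and "the series" means these few. Any claim that something is new, unique, unknown or untested is made for them only; others in the source may bear on it.

Working notes on the series. The shared core is carried by compound 1 `Cn1c(=O)c(S(=O)(=O)c2ccc(F)cc2F)cc2cnc(Nc3cccc4[nH]ccc34)nc21` and compound 2 `Cn1c(=O)c(C(=O)Nc2ccc(F)cc2)cc2cnc(Nc3ccc4[nH]ccc4c3)nc21`. In a functional assay on K562 cells (Homo sapiens) for inhibition, read by trypan blue exclusion, with a stated time of 72 h (a higher number here means a weaker inhibitor, a lower number a stronger inhibitor), compound 1 gives 1500 nM, the lowest of the two numbers recorded, while compound 2 gives 5000 nM in this assay, a gap beyond the scatter; these two differ in more than one place, so only the two values themselves are noted. Compound 3 `Cn1c(=O)c(S(=O)(=O)c2ccc(F)cc2F)cc2cnc(Nc3cnc4[nH]ccc4c3)nc21` differs from compound 1 by a group of 9 heavy atoms (7 carbon, 2 nitrogen; one five-membered aromatic ring with 1 hetero atom, one six-membered aromatic ring with 1 hetero atom) in place of a group of 9 heavy atoms (8 carbon, 1 nitrogen; one five-membered aromatic ring with 1 hetero atom, one six-membered aromatic ring of carbon only), on a nitrogen on an aromatic ring. With no measured step of this kind in the set, the expectation for compound 3 is a step of a 1.2-fold higher number from compound 1 to compound 3 (0.08 log units; within the scatter), that is, no step beyond the scatter. Compound 3 is accordingly estimated at 1800 nM in this assay, within a range of 600 nM to 5000 nM.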

Compound 3, half-maximal inhibitory concentration: 750 nM
Compound 3: middle estimate off by 2.4-fold (0.38 log units), on the high side, and the stated range covers the measured number.
By their numbers in this assay, from the lowest: compounds 3 and 1 (each within the scatter of the next); then compound 2.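

Exchanging the 1H-indol-4-yl on a nitrogen on an aromatic ring for the group with a hetero atom in its six-membered aromatic ring gives a 2.0-fold lower number from compound 1 to compound 3 (0.30 log units; within the scatter) in this assay, so this single change shifts the number by no more than the scatter. Going by these compounds alone, this is the first one-place comparison, and it shows that this position accepts that added ring nitrogen without a step beyond the scatter. No measurement on hand bears on the reason for this result.

On these data alone, it remains open how a phenyl carrying a morpholine would read at this position. As far as these compounds go, the separate contributions of the sulfonyl and amide groups also remain open, since compound 1 and compound 2 differ in more than one place.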